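The source may hold more compounds than are shown below. What is called first, only, known or untested is meant among the compounds shown, and "the series" means these compounds.

Measured in a toxicity assay on HepG2 2.2.15 cells (Homo sapiens) for cytotoxicity, read by CellTiter-Glo; a higher number here means that more compound is tolerated, a lower number that less compound is tolerated:
- compound 1 `O=C1CC(c2ccc(F)cn2)CN1c1cnn2c1CN(C(=O)Nc1cc(F)c(F)c(F)c1)C(C1CC1)C2`: 38500 nM
- compound 2 `Cc1nc(C2CC(=O)N(c3cnn4c3CN(C(=O)Nc3cc(F)c(F)c(F)c3)C(C3CC3)C4)C2)no1`: > 200000 nM, a limit of the assay and not a number

Compound 2 has no number to start from, only a limit: the limit of > 200000 nM in this assay, at which 1 of the 2 values shown sits. Compound 3 `O=C1CC(c2ccccc2)CN1c1cnn2c1CN(C(=O)Nc1cc(F)c(F)c(F)c1)C(C1CC1)C2` is not yet measured. It carries phenyl in place of 5-methyl-1,2,4-oxadiazol-3-yl on a saturated ring carbon. Within the data shown here, only one measured step bears on this change: an at least 5.1-fold higher number from compound 1 to compound 2 (0.71 log units; beyond the scatter). That step introduced the same 5-methyl-1,2,4-oxadiazol-3-yl in place of 5-fluoropyridin-2-yl at the same carbon, and its size is only a lower bound. Compound 3 removes that group again and puts back a six-membered aromatic ring, so the nearest reference is compound 1 at 38500 nM. A move of at least modest size towards a lower number is therefore expected, beyond the scatter. The estimated step is an at least 6.2-fold lower number from compound 2 to compound 3 (0.79 log units; beyond the scatter). Among the measured compounds shown here, no measured step compares phenyl directly with 5-fluoropyridin-2-yl, so the range stays wide. For compound 3 the expected value is 32000 nM, with an estimated range of 11000 nM to 95000 nM.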

Compound 3, half-maximal cytotoxic concentration: 12800 nM
Compound 3: middle estimate off by 2.5-fold (0.40 log units), on the high side, within the range that was stated.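

In this assay, phenyl in place of 5-fluoropyridin-2-yl on this saturated ring carbon gives a 3.0-fold lower number from compound 1 to compound 3 (0.48 log units; beyond the scatter), so the two six-membered aromatic rings are not interchangeable at this position. Phenyl in place of 5-methyl-1,2,4-oxadiazol-3-yl gives an at least 15-fold lower number from compound 2 to compound 3 (1.19 log units; beyond the scatter), which places the three compounds in the order compound 3, compound 1, compound 2 from the lowest tolerated concentration upward, with each step beyond the scatter. Compound 2 has a limit and not a number, so the size of its steps stays a bound: the limit of > 200000 nM in this assay, at which 1 of the 3 values shown sits.

Phenyl and 5-fluoropyridin-2-yl differ in both the ring nitrogen and the fluorine, so the share of each in the step remains open, and a pyridin-2-yl without the fluorine would help to separate them. Also open, from the compounds shown here alone, is how a non-aromatic group on this carbon, such as an amine or a carboxylic acid, would read in this assay, and whether a second five-membered aromatic ring would follow 5-methyl-1,2,4-oxadiazol-3-yl.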